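The source may report more compounds than this note shows. Statements on the series, on what has been measured and on what is new or still open speak of the compounds shown alone.

Measured compounds in an ADME assay on microsomes from liver (Homo sapiens) for metabolic stability, using NADPH, with a stated time of 30 min, in the presence of a further agent that is not named here; a lower number here means that less of the compound is left, a higher number that more of the compound is left:
compound 1, `CCOC(=O)C1c2c[nH]nc2CCN1S(=O)(=O)c1ccc(Cl)cc1`: 1%
compound 2, `O=S(=O)(c1ccc(Cl)cc1)N1Cc2c[nH]nc2CC1c1nccs1`: 54%
compound 3, `O=S(=O)(c1ccc(Cl)cc1)N1CCc2n[nH]cc2C1c1cncnc1`: 50%

Compound 2 gives the highest of the three numbers in this assay. Compound 3 stands nearest to it, and the two numbers lie within the scatter of each other, so no order between compound 2 and compound 3 is claimed. Compound 1 stands furthest from compound 2, beyond the scatter.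

Among the measured compounds shown here, the only measured step that exchanges the group on the saturated ring carbon is a number 49 percentage points higher from compound 1 to compound 3 (beyond the scatter). It shows that an aromatic ring at this carbon gives a far higher number than ethoxycarbonyl. For the measured compounds named here, no measured step exchanges one aromatic ring for another at this carbon; compound 2 and compound 3 simply show that a five-membered and a six-membered heteroaromatic ring there give numbers within the scatter of each other.

Compound 4, `O=S(=O)(c1ccc(Cl)cc1)N1Cc2c[nH]nc2CC1c1cc(F)cc(F)c1`, is not yet measured. It differs from compound 2 in one place: 3,5-difluorophenyl in place of 1,3-thiazol-2-yl on a saturated ring carbon

The change keeps an aromatic ring on that carbon, as in compound 2 and compound 3, so a number in the same region is expected in this assay, with a small downward step at most. The expected step is a number 12 percentage points lower from compound 2 to compound 4 (beyond the scatter). For compound 4 the estimate is 42%, in a range from 15% to 70%.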

Compound 4, percent of the compound remaining: 3%
For compound 4 the middle estimate is 39 percentage points above the measured one; the measured number lies below the stated range.
By their numbers in this assay, from the lowest: compounds 1 and 4 (each within the scatter of the next); then compounds 3 and 2 (each within the scatter of the next).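

In this assay, the exchange of 1,3-thiazol-2-yl for 3,5-difluorophenyl on the saturated ring carbon gives a number 51 percentage points lower from compound 2 to compound 4 (beyond the scatter). An aromatic ring on this carbon is therefore not enough in itself for a high number, a reading that a number 49 percentage points higher from compound 1 to compound 3 (beyond the scatter) had left possible; on the core of compound 2, the choice of aromatic ring has a large effect on the result. No measured information on the compounds accounts for this step.

The change replaces a five-membered aromatic ring holding nitrogen and sulfur with a six-membered aromatic ring of carbon only that also carries fluorine, so the contributions of ring size, ring hetero atoms and fluorine remain unseparated in compound 4. Unsubstituted phenyl would separate the fluorine atoms from the carbon-only ring, and pyridin-3-yl would test a six-membered ring with a ring nitrogen, while it also remains open whether 3,5-difluorophenyl has the same effect on the core of compound 3.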